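A Flat Series Faces an Ethoxycarbonyl Extension

The source may report more compounds than this note shows. Statements on the series, on what has been measured and on what is new or still open speak of the compounds shown alone.

Of the compounds shown here, three sharing one core have been measured in a functional assay on LoVo cells (Homo sapiens) for cytotoxicity, read by colorimetric assay and MTT assay; on this read-out higher numbers stand for weaker inhibition and lower numbers for stronger inhibition. Compound 1 `COc1ccc(-c2cc3cccc(OC)c3nc2O)cc1` gives 10000 nM in this assay. Compound 2 `COc1ccc(-c2cc3c(OC)ccc(OC)c3nc2O)cc1`, which carries methoxy in place of hydrogen on an aromatic carbon, gives 10000 nM in this assay, and the step of no change at the digits printed from compound 1 to compound 2 (within the scatter) is flat. Compound 3 `COc1ccc(-c2cc3c(OC)cc(OC)cc3n(C)c2=O)cc1` gives 10000 nM in this assay, level with compound 1 and compound 2 at the digits shown, so it is neither more nor less active than either within the scatter.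

Compound 4 `CCOC(=O)Cn1c(=O)c(-c2ccc(OC)cc2)cc2c(OC)cc(OC)cc21` is not yet measured. It differs from compound 3 by ethoxycarbonyl in place of hydrogen on a saturated chain carbon bound to an aromatic nitrogen; cut one bond further out, the change reads methyl to (ethoxycarbonyl)methyl. Among the measured compounds shown here, no measured step touches this saturated chain carbon; the only measured step, no change at the digits printed from compound 1 to compound 2 (within the scatter), concerns an aromatic carbon and shows no change. Since every measured value sits at one level, the step of no change at the digits printed from compound 3 to compound 4 (within the scatter) is expected to stay within the scatter. Compound 4 is therefore estimated at 10000 nM, in the range 4000 nM to 25000 nM.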

Compound 4, half-maximal inhibitory concentration: 10000 nM
The estimate for compound 4 equals the measured number at the digits printed; the range from low to high includes it.
By their numbers in this assay, from the lowest: compounds 1, 2, 3 and 4 (each within the scatter of the next).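

In this assay, among the compounds shown here, the first measured change at a saturated chain carbon bound to an aromatic nitrogen, ethoxycarbonyl in place of hydrogen, reads no change at the digits printed from compound 3 to compound 4 (within the scatter). This position therefore carries the change from methyl to (ethoxycarbonyl)methyl with no shift in the value, and the aromatic carbon step reads the same way, no change at the digits printed from compound 1 to compound 2 (within the scatter), so neither of the two measured changes separates its pair of compounds in this read-out. Nothing available explains why the value holds at this position.

On these data alone, whether a carboxylic acid in place of the ethoxycarbonyl, or an amine or a longer chain on the same saturated carbon, would move away from the value of compound 4, 10000 nM, remains open. The compounds shown also leave open whether any change to the shared core gives a value off this common level.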